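Anilide substituent exchange in an antiproliferative series

The source may report more compounds than this note shows. Statements on the series, on what has been measured and on what is new or still open speak of the compounds shown alone.

Two compounds of a shared core have been run in a functional assay on HCT-116 cells (Homo sapiens) for antiproliferative activity, read by MTT assay, with a stated time of 72 h; on this read-out lower numbers stand for stronger inhibition and higher numbers for weaker inhibition. Compound 1 `CC(C)(C)OC(=O)Nc1ccc(NC(=O)CCc2cccc3c2B(O)OC3)cc1` gives 24000 nM. Compound 2 `C#Cc1cccc(NC(=O)CCc2cccc3c2B(O)OC3)c1` gives 3600 nM, the lower of the two numbers; its gap to compound 1 lies beyond the scatter. Compound 3 `O=C(CCc1cccc2c1B(O)OC2)Nc1cccc(-c2cccc(C(F)(F)F)c2)c1` is not yet measured. It differs from compound 2 in one place: 3-(trifluoromethyl)phenyl in place of ethynyl on an aromatic carbon. Among the measured compounds shown here, no pair of measured compounds shows this kind of exchange, so there is no measured step to lean on. The ring that enters carries no hydrogen-bond donors or acceptors, as the ethynyl it replaces carries none. The expectation for compound 3 is a number close to that of compound 2, with a modest lowering as the more likely direction, the step of a 1.8-fold lower number from compound 2 to compound 3 (0.26 log units; within the scatter) staying near the edge of the scatter. Compound 3 is estimated at 2000 nM, within 500 nM to 8000 nM.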

Compound 3, half-maximal inhibitory concentration: 580 nM
Compound 3: the middle estimate sits 3.4-fold (0.54 log units) above what was measured, and the stated range covers the measured number.
By their numbers in this assay, from the lowest: compound 3; then compound 2; then compound 1.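

In this assay, among the compounds shown here, the aromatic carbon that carries ethynyl in compound 2 also takes the larger 3-(trifluoromethyl)phenyl, and the exchange gives a 6.2-fold lower number from compound 2 to compound 3 (0.79 log units; beyond the scatter) as the first step that can be read at a single place. Here a second six-membered aromatic ring of carbon only, bringing no hydrogen-bond donors or acceptors, goes with a lower number on this read-out, so the added bulk is tolerated at this position in this one comparison. No measurement at hand bears on what lies behind the lower number.

An unsubstituted phenyl at this place would separate the contribution of the ring from that of the trifluoromethyl on it. As far as these compounds go, whether a ring carrying an amine or a carboxylic acid would keep the lower number remains open.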